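The source may report more compounds than this note shows. Statements on the series, on what has been measured and on what is new or still open speak of the compounds shown alone.

Compound 1 `COc1cc(/C=C/C(=O)/C=C(/C=C/c2ccc(OC(C)=O)c(OC)c2)NC2CCCCC2)ccc1OC(C)=O`: 0.01%
Compound 2 `CCC(C)NC(=C\C(=O)/C=C/c1ccc(O)c(OC)c1)/C=C/c1ccc(O)c(OC)c1`: 0.13%
Compound 3 `CC(C)CNC(=C\C(=O)/C=C/c1ccc(O)cc1)/C=C/c1ccc(O)cc1`: 0.02%

These numbers come from a functional assay for inhibition, read by spectrophotometry, with a stated time of 30 min, tested at 1 uM (on this read-out lower numbers stand for less inhibition and higher numbers for more inhibition at the one concentration tested (going by the name of the read-out)), where all three compounds show essentially no inhibition. Compound 2 cannot be told apart from compound 3 or compound 1, as each gap lies within the usual scatter.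

Compound 4 `COc1cc(/C=C/C(=O)/C=C(/C=C/c2ccc(O)c(OC)c2)NC2CCCCC2)ccc1O` differs from compound 2 in one place: cyclohexyl in place of sec-butyl on an amine nitrogen. Within the data shown here, no pair of measured compounds differs in just this way, so nothing here shows how this exchange moves the read-out. Compounds 1, 2 and 3 differ in several places yet all sit near zero, so no step beyond the scatter is expected in this assay. Compound 4 is expected to give about 0.2%, between 0% and 8%, an estimated step of a number 0.1 percentage points higher from compound 2 to compound 4 (within the scatter).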

Compound 4, a percentage reported as inhibition, at one concentration (the size of the read-out at that concentration, not a potency): 0.13%
Estimate against measurement, compound 4: 0.1 percentage points above, within the range that was stated.
By their numbers in this assay, from the lowest: compounds 1, 3, 2 and 4 (each within the scatter of the next).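

In this assay, among these compounds, putting cyclohexyl in place of sec-butyl on the amine nitrogen gives no change at the digits printed from compound 2 to compound 4 (within the scatter) and offers the first comparison in which only this position differs. Adding a six-membered carbon ring here does not lift the read-out away from essentially no inhibition at the one concentration tested. No measurement shown explains this result.

Going by these compounds, it remains open whether a carboxylic acid or an amine at the end of a longer chain on this nitrogen would change the read-out. Nor do these compounds show whether changing any other part of the shared core would do so.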